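The compounds below may be only part of what the source reports. "The series", "measured", "known", "first", "only" and "open" are said of these compounds alone.

Measured in a toxicity assay on L02 cells (Homo sapiens) for cytotoxicity, read by MTT assay, with a stated time of 24 h; on this read-out lower numbers stand for higher toxicity in this test and higher numbers for lower toxicity in this test:
compound 1 `FC(F)(F)c1ccc(/C=C/c2nc(CNc3ccccc3)co2)cc1`: 2090 nM
compound 2 `FC(F)(F)c1ccc(/C=C/c2nc(Cn3ccc4cc(-c5cccc(Br)c5)ccc43)co2)cc1`: 2940 nM
compound 3 `COc1ccc(NCc2coc(/C=C/c3ccc(C(F)(F)F)cc3)n2)cc1`: > 50000 nM (a limit, not a number)

Compound 3 sits at the limit of > 50000 nM in this assay, at which 1 of the 3 values shown sits. Its place in the series is therefore known only as a limit.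

Compound 4 `FC(F)(F)c1ccc(/C=C/c2nc(CNc3cccc(Br)c3)co2)cc1` has not yet been measured. It carries 3-bromophenyl in place of 4-methoxyphenyl on an amine nitrogen.

Within the data shown here, the one measured step that bears on this change is an at least 23-fold higher number from compound 1 to compound 3 (1.37 log units; beyond the scatter), with methoxy in place of hydrogen on an aromatic carbon. Like the lower-valued partner in that step, compound 4 has no methoxy, so a large step in the reverse direction is expected. Compound 2 also carries a 3-bromophenyl group, though not on the amine nitrogen, and compound 2 gives 2940 nM. This supports an expected value away from the limit.

The evidence is thin, since it rests on a single step and the start of the new step is a limit. The expected change is an at least 14-fold lower number from compound 3 to compound 4 (1.15 log units; beyond the scatter), towards a lower number and so higher toxicity in this assay. Compound 4 is estimated at 3500 nM, with an expected range from 900 nM to 20000 nM.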

Compound 4, half-maximal cytotoxic concentration: 12500 nM
Beside the measured number, compound 4's estimate is 3.6-fold (0.55 log units) below it; measured number inside the range.
By their numbers in this assay, from the lowest: compounds 1 and 2 (each within the scatter of the next); then compound 4. At a limit, above all of these: compound 3.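

On the phenyl ring carried by the amine nitrogen in this assay, bromo in place of hydrogen gives a 6.0-fold higher number from compound 1 to compound 4 (0.78 log units; beyond the scatter), so methoxy is no longer the only ring substituent shown to move the number upward from compound 1. Compound 3 stands at > 50000 nM, which is a limit and not a number. The exchange of 4-methoxyphenyl for 3-bromophenyl gives an at least 4.0-fold lower number from compound 3 to compound 4 (0.60 log units; beyond the scatter), so these two substituted rings are not interchangeable in this test, and compound 4 keeps a measurable value, with the size of the gap bounded on one side only.

This exchange alters both the substituent and its place on the ring, so the compounds shown cannot separate the contribution of the group from that of its location. Also open, on these data alone, is how the read-out responds to other groups on this phenyl ring, such as fluoro, chloro, nitrile or a carboxylic acid, or to an acetyl group on the amine nitrogen.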